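Trading the Chlorobenzyl Arm for Ethyl

A few compounds are considered here, and "the series" means these few. Any claim that something is new, unique, unknown or untested is made for them only; others in the source may bear on it.

Compound 1 `C=C(Br)C(=O)Nc1ccc(/C=C2\SC(=O)N(Cc3cccc(Cl)c3)C2=O)cc1`: 3400 nM
Compound 2 `Nc1cccc(/C=C2\SC(=O)N(Cc3cccc(F)c3)C2=O)c1`: 199000 nM
Compound 3 `Nc1ccc(/C=C2\SC(=O)N(Cc3cccc(Cl)c3)C2=O)cc1`: 4700 nM

In a functional assay on L1210 cells (Mus musculus) for cytotoxicity, read by cell counting, with a stated time of 2 days (on this read-out lower numbers stand for stronger inhibition and higher numbers for weaker inhibition), compound 1 gives 3400 nM, the lowest of the three numbers. Going by the values given here, its nearest neighbour is compound 3, where the only measured step, a 1.4-fold higher number from compound 1 to compound 3 (0.14 log units; within the scatter), stays within the scatter. Compound 2, with 199000 nM, lies far beyond the scatter from compound 1; it differs from compound 3 in two places, so only the two values themselves can be compared.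

Compound 4 `C=C(Br)C(=O)Nc1ccc(/C=C2\SC(=O)N(CC)C2=O)cc1` is the new compound. It differs from compound 1 by methyl in place of 3-chlorophenyl on a saturated chain carbon bound to an amide-type nitrogen in a ring. Among the compounds with values here, the one measured step, a 1.4-fold higher number from compound 1 to compound 3 (0.14 log units; within the scatter), alters a different part of the molecule, so no measured step bears on this change. All three measured compounds carry the 3-chlorophenyl or a close relative, and its removal takes away a whole aromatic ring, which makes a weakening more likely than a gain. For compound 4 the expected result is 10000 nM (range 2500 nM to 40000 nM), an estimated step of a 2.9-fold higher number from compound 1 to compound 4 (0.47 log units; beyond the scatter).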

Compound 4, half-maximal inhibitory concentration: 500 nM
Compound 4: middle estimate off by 20-fold (1.30 log units), on the high side, and the stated range ends above it.
By their numbers in this assay, from the lowest: compound 4; then compounds 1 and 3 (each within the scatter of the next); then compound 2.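

In this assay, trading the 3-chlorobenzyl arm for ethyl gives a 6.8-fold lower number from compound 1 to compound 4 (0.83 log units; beyond the scatter), so at this position the aromatic ring with its chlorine can go and the number still drops clearly. The earlier compounds shown here all carried a halogen-bearing benzyl arm, so they could not show that a much smaller group is tolerated here, or that it can give the lower number. Nothing at hand explains why the ethyl compound gives the lower number.

As far as these compounds go, what remains open is how the number depends on the size of this group: a propyl or longer chain, a plain methyl or an unsubstituted benzyl could each show whether the trend is smooth or specific to ethyl. From the compounds shown here alone, this is also one pair, so it remains unknown whether the same change would lower the number with other groups on the shared core.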